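Replacing an Amide with a Dichlorophenyl Urea

This account rests on a few compounds, and the source may have more. Where it says the series, first, only, none or still open, it means among the compounds named here.

Measured compounds:
Compound 1, `COc1cc(-c2nn(-c3cccc(NC(=O)c4ccc(Cl)c(C(F)(F)F)c4)c3)cc2-c2ccncc2)ccc1Cl`, gives 1740 nM in a functional assay on MDA-MB-435 cells (Homo sapiens) for inhibition, read by sulforhodamine B assay, with a stated time of 48 h; on this read-out higher numbers stand for weaker inhibition of growth and lower numbers for stronger inhibition of growth.
Compound 2, `COc1cc(-c2nn(-c3cccc(NC(=O)Nc4ccc(Cl)c(C(F)(F)F)c4)c3)cc2-c2ccncc2)ccc1Cl`, gives 1690 nM in this assay.
Compound 3, `O=C(Nc1cccc(-n2cc(-c3ccncc3)c(-c3ccc(Cl)c(O)c3)n2)c1)Nc1ccc(Cl)c(C(F)(F)F)c1`, gives 1770 nM in this assay.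

Among these three numbers compound 1 stands second highest, with compound 3 nearest and compound 2 furthest, yet every one of these gaps lies within the scatter, so the three compounds cannot be told apart in this assay. Compound 4, `COc1cc(-c2nn(-c3cccc(NC(=O)Nc4ccc(Cl)c(Cl)c4)c3)cc2-c2ccncc2)ccc1Cl`, has not yet been measured. It differs from compound 1 in one place: (3,4-dichlorophenyl)amino in place of 4-chloro-3-(trifluoromethyl)phenyl on a carbonyl carbon. Within the data shown here, one measured step bears directly on this change: a 1.0-fold lower number from compound 1 to compound 2 (0.01 log units; within the scatter), where the same kind of exchange on the carbonyl carbon, from an aryl group to an arylamino group, left the number within the scatter. Among the measured compounds shown here, no measured step shows what exchanging the trifluoromethyl for a second chlorine does. The expected step is therefore a 1.0-fold lower number from compound 1 to compound 4 (0.01 log units; within the scatter), that is, no movement beyond the scatter. Compound 4 is estimated at 1700 nM, within a range from 800 nM to 3600 nM.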

Compound 4, concentration for total growth inhibition: 2390 nM
Beside the measured number, compound 4's estimate is 1.4-fold (0.15 log units) below it; measured number inside the range.
By their numbers in this assay, from the lowest: compounds 2, 1, 3 and 4 (each within the scatter of the next).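

In this assay, among these compounds, chloro in place of trifluoromethyl on the aromatic carbon gives a 1.4-fold higher number from compound 2 to compound 4 (0.15 log units; within the scatter), the first measured look at this exchange on the aryl group of the urea. The full replacement on the carbonyl carbon, which swaps the aryl group of the amide for the (3,4-dichlorophenyl)amino group of the urea, gives a 1.4-fold higher number from compound 1 to compound 4 (0.14 log units; within the scatter), so compound 4 cannot be told apart from either compound 1 or compound 2. Nothing available here gives a reason for these numbers.

All four compounds keep a chlorine on this aryl group and either a second chlorine or a trifluoromethyl with it. The compounds shown therefore leave open whether a nitrile, an amine or a carboxylic acid there would move the number beyond the scatter.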